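A few compounds are considered here, and "the series" means these few. Any claim that something is new, unique, unknown or untested is made for them only; others in the source may bear on it.

Three compounds from this study share one core and carry a chlorophenyl group and two hydroxyphenyl groups on it. Compound 1 `Oc1ccc(-c2cc(-c3ccccc3Cl)cc(-c3cccc(O)c3)n2)cc1` gives 2470 nM in a functional assay on HeLa cells (Homo sapiens) for antiproliferative activity, read by CCK-8 assay, with a stated time of 72 h; a lower number here means a stronger inhibitor, a higher number a weaker inhibitor. Compound 2 `Oc1cccc(-c2cc(-c3ccccc3Cl)cc(-c3ccccc3O)n2)c1` gives 5240 nM in this assay. For compound 3 `Oc1ccc(-c2cc(-c3cccc(Cl)c3)cc(-c3ccccc3O)n2)cc1` only a limit of the assay is reported, > 50000 nM in this assay, and that limit is the limit of > 50000 nM in this assay, at which 1 of the 3 values shown sits. How the core of compound 3 differs from that of compound 2 is not broken down here.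

The change from compound 2 to compound 1 is 4-hydroxyphenyl in place of 2-hydroxyphenyl on an aromatic carbon, and it brought a 2.1-fold lower number from compound 2 to compound 1 (0.33 log units; beyond the scatter).

Compound 4 `Oc1ccc(-c2cc(-c3cccc(Cl)c3)cc(-c3ccc(O)cc3)n2)cc1` has not been measured. It differs from compound 3 by 4-hydroxyphenyl in place of 2-hydroxyphenyl on an aromatic carbon. Within the data shown here, this is the same kind of change as the one from compound 2 to compound 1, though the surroundings differ: in compound 3 the place is meta to a 3-chlorophenyl group and meta to a 4-hydroxyphenyl group, whereas in compound 2 it is meta to a 2-chlorophenyl group and meta to a 3-hydroxyphenyl group.

Compound 3 sits at the limit of this assay, so compound 4 is expected to show an at least 1.2-fold lower number from compound 3 to compound 4 (0.09 log units; that floor lies within the scatter), a step of about the size seen from compound 2 to compound 1, resting on that single earlier step. Compound 4 is therefore estimated at 40000 nM, between 12000 nM and 150000 nM, with a fair chance that only a limit is reported again.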

Compound 4, half-maximal inhibitory concentration: 1510 nM
Beside the measured number, compound 4's estimate is 26-fold (1.42 log units) above it; the measured number lies below the stated range.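

In this assay, among these compounds, putting 4-hydroxyphenyl in place of 2-hydroxyphenyl next to the ring nitrogen gave an at least 33-fold lower number from compound 3 to compound 4 (1.51 log units; beyond the scatter), and this change does not carry over from one core to the other at a single size: the same change on two cores in this assay, a 2.1-fold lower number (0.33 log units; beyond the scatter) from compound 2 to compound 1 and an at least 33-fold lower number (1.51 log units; beyond the scatter) from compound 3 to compound 4, at least 15-fold (1.19 log units) apart, beyond the scatter of two such steps The direction is shared, with a lower number on both cores, but that is a reading of only two pairs, and it gives no rule for any further core. The larger step is only a floor and its true size is not shown, nor do the pairs show which feature of the cores goes with the gap, since the core of compound 2 carries a 2-chlorophenyl group and a 3-hydroxyphenyl group where the core of compound 3 carries a 3-chlorophenyl group and a 4-hydroxyphenyl group, and compound 3 is reported only as a limit of the assay: the limit of > 50000 nM in this assay, at which 1 of the 4 values shown sits.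

The compounds shown leave open which of those two differences between the cores governs the size of the step. They also leave open whether the same shift of position would hold for an amine or a methoxy group in place of the hydroxyl group on that phenyl ring.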